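The source may report more compounds than this note shows. Statements on the series, on what has been measured and on what is new or still open speak of the compounds shown alone.

The measured compounds are:
compound 1, `CC(C(=O)NCc1ccc(C(F)(F)F)nc1-c1ccccc1)c1ccc(NS(C)(=O)=O)c(F)c1`, which in an assay on CHO cells for antagonist activity at transient receptor potential cation channel subfamily V member 1 (Homo sapiens), read by FLIPR (on this read-out lower numbers stand for stronger inhibition and higher numbers for weaker inhibition), gives 6.4 nM;
compound 2, `CC(C(=O)NCc1ccc(C(F)(F)F)nc1-c1ccc2cc[nH]c2c1)c1ccc(NS(C)(=O)=O)c(F)c1`, which in this assay gives 20.3 nM.

For the measured compounds named here, compound 2 stands at the higher of the two numbers; its nearest neighbour is compound 1, and the only measured step, a 3.2-fold higher number from compound 1 to compound 2 (0.50 log units; beyond the scatter), shows that exchanging the aromatic group on that carbon of the shared core shifts the number modestly but beyond the scatter.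

Compound 3, `CC(C(=O)NCc1ccc(C(F)(F)F)nc1CCc1ccc(F)cc1)c1ccc(NS(C)(=O)=O)c(F)c1`, is not yet measured. It differs from compound 2 by 2-(4-fluorophenyl)ethyl in place of 1H-indol-6-yl on an aromatic carbon, the group entering being 2-(4-fluorophenyl)ethyl, with no hydrogen-bond donor where the indolyl group carried one. Going by the values given here, no measured step covers a change of this kind; the step from compound 1 to compound 2 only shows that this position tolerates a change of aromatic group with a modest shift. The estimate therefore rests on that single step, and a modest further weakening is expected, a 1.5-fold higher number from compound 2 to compound 3 (0.17 log units; within the scatter), with a wide range. Compound 3 is expected to give about 30 nM in this assay, between 8 nM and 120 nM.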

Compound 3, inhibition constant: 1.8 nM
Compound 3: middle estimate off by 17-fold (1.22 log units), on the high side; measured number outside the range, below it.
By their numbers in this assay, from the lowest: compound 3; then compound 1; then compound 2.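

In this assay, the aromatic carbon next to the ring nitrogen accepts more than a ring attached directly, since 2-(4-fluorophenyl)ethyl gives an 11-fold lower number from compound 2 to compound 3 (1.05 log units; beyond the scatter) and a 3.6-fold lower number from compound 1 to compound 3 (0.55 log units; beyond the scatter) in the same read-out. For the compounds shown here, the one earlier step had only raised the number, whereas these two, both beyond the scatter, show that a change at this position can also lower it, with the ring held on a chain. The change from 1H-indol-6-yl removes a hydrogen-bond donor, but it also brings in the chain and the fluorine, so these compounds cannot separate the three changes. Nothing measured here accounts for the shift.

What the fluorine contributes remains open, as the compounds shown offer no comparison with an unsubstituted 2-phenylethyl group. Also open, from the compounds shown here alone, is whether a longer chain such as 3-phenylpropyl, or a chain carrying an amine or an ether oxygen, would keep the low number seen with compound 3.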